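Swapping chloro for methoxy on a triphosphate agonist

The source may hold more compounds than are shown below. What is called first, only, known or untested is meant among the compounds shown, and "the series" means these compounds.

Compound 1, `O=P(O)(O)OP(=O)(O)OP(=O)(O)OC[C@H]1O[C@@H](c2nc3ccc(Cl)cc3s2)[C@H](O)[C@@H]1O`: 8 nM
Compound 2, `Cc1ccc2oc([C@@H]3O[C@H](COP(=O)(O)OP(=O)(O)OP(=O)(O)O)[C@@H](O)[C@H]3O)nc2c1`: 390 nM
Compound 3, `O=P(O)(O)OP(=O)(O)OP(=O)(O)OC[C@H]1O[C@@H](c2nc3c(F)cc(Cl)cc3s2)[C@H](O)[C@@H]1O`: 7 nM

Of the compounds shown here, three have been measured in a functional assay for agonist activity at P2Y purinoceptor 2 (Homo sapiens), read by FLIPR; a lower number here means that less compound is needed, a higher number that more compound is needed for the effect. Compound 1 gives 8 nM, and compound 3 gives 7 nM, so the two sit within the scatter of each other; the change a 1.1-fold lower number from compound 1 to compound 3 (0.06 log units; within the scatter) is therefore of no weight. Compound 2 is far apart: the change a 49-fold higher number from compound 1 to compound 2 (1.69 log units; beyond the scatter) is large and well beyond the scatter. Compound 1 thus stands with compound 3 at the strong end of the three, with compound 2 the outlier.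

Compound 4, `COc1ccc2nc([C@@H]3O[C@H](COP(=O)(O)OP(=O)(O)OP(=O)(O)O)[C@@H](O)[C@H]3O)sc2c1`, keeps the shared core of compound 1 and changes only one substituent: methoxy in place of chloro on an aromatic carbon. Among the measured compounds shown here, no measured step exchanges one group for another at this position, so the bearing of the earlier steps is indirect. The step to compound 3 shows that one added fluoro on the aromatic ring left the number unchanged, while the step to compound 2 shows that reworking the whole bicyclic unit cost a great deal. Replacing chloro by methoxy lies between these cases, and a modest rise in the number is expected for compound 4, the step of a 2.5-fold higher number from compound 1 to compound 4 (0.40 log units; beyond the scatter) being the estimate. For compound 4 the expected value is 20 nM, within 5 nM to 100 nM.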

Compound 4, half-maximal effective concentration: 42 nM
For compound 4 the middle estimate is 2.1-fold (0.32 log units) below the measured one, and the stated range covers the measured number.
By their numbers in this assay, from the lowest: compounds 3 and 1 (each within the scatter of the next); then compound 4; then compound 2.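

In this assay, methoxy in place of chloro on this aromatic carbon gives a 5.3-fold higher number from compound 1 to compound 4 (0.72 log units; beyond the scatter) and so lies beyond the scatter, which shows that the number responds to the group held at this position. The earlier fluoro step, a 1.1-fold lower number from compound 1 to compound 3 (0.06 log units; within the scatter), lay within the scatter, so compound 3 gave no sign that a change on the aromatic ring could move the number, whereas compound 4 does. Even so, this single exchange is a much smaller step than a 49-fold higher number from compound 1 to compound 2 (1.69 log units; beyond the scatter), in which the whole group on the saturated ring carbon differs, and no measurement available here explains why methoxy raises the number.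

From the compounds shown here alone, with only chloro and methoxy to compare at this position, it remains open whether a bromo group, an amine or a carboxylic acid would bring the number close to that of compound 1 or move it further away. Also open, going by these compounds, are whether a longer chain such as ethoxy would raise the number beyond that of compound 4, and whether the added fluoro of compound 3 would still leave the number unchanged with methoxy in place of chloro.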